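The source may report more compounds than this note shows. Statements on the series, on what has been measured and on what is new or still open speak of the compounds shown alone.

Compound 1 `OC[C@H](NC[C@H]1N[C@H](CO)[C@H](O)[C@@H]1O)c1ccccc1` gives 11800 nM in an assay on isolated protein for inhibition of alpha-mannosidase 2 (Homo sapiens); a higher number here means a weaker inhibitor, a lower number a stronger inhibitor.
Compound 2 `O[C@H]1[C@@H](O)CN[C@@H]1CN[C@@H](COCOc1ccc(F)cc1)c1ccccc1` gives 6470 nM in this assay.
Compound 3 `C[C@H](O)NC[C@H]1NC[C@H](O)[C@@H]1O` gives 683000 nM in this assay.

Compound 3 carries the highest number of the three, and its distance to compound 1, the nearest of the other two, as well as to compound 2 lies beyond the scatter. It is therefore the weakest inhibitor in this small set.

Compound 4 `C[C@@H](O)NC[C@H]1NC[C@H](O)[C@@H]1O` is the next member. Against compound 3 the change is the two compounds have the same atoms and bonds and differ only in configuration as drawn: 1 of 4 stereo elements differ; a stereocentre at a saturated chain carbon is drawn S in compound 3 and R in compound 4. Going by the values given here, no pair of measured compounds in the set differs only in configuration, so there is no step within these data to calibrate such a change against, and the two compounds that are far stronger than compound 3 differ from it in much more than configuration.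

Among the compounds with values here, for a change of configuration alone, with no comparable step in hand, the expectation is a step of no set direction and of a size within the scatter, while leaving room for a larger shift either way. Compound 4 is expected to give 550000 nM in this assay, with a range from 150000 nM to 2000000 nM. The step from compound 3 to compound 4 is thus estimated as a 1.2-fold lower number from compound 3 to compound 4 (0.09 log units; within the scatter).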

Compound 4, inhibition constant: 450000 nM
Compound 4: middle estimate off by 1.2-fold (0.09 log units), on the high side, and the stated range covers the measured number.
By their numbers in this assay, from the lowest: compounds 2 and 1 (each within the scatter of the next); then compounds 4 and 3 (each within the scatter of the next).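

With a 1.5-fold lower number from compound 3 to compound 4 (0.18 log units; within the scatter), the series gains its first step in which configuration alone changes, so the effect of this change can be read without any other change in the structure. In this assay, going from S to R at this saturated chain carbon gives no change beyond the scatter, which marks this stereocentre, in this pair, as one where the drawn configuration makes no measurable difference. The step can be assigned to this single stereocentre and to nothing else: the fact that compounds 3 and 4 differ only in the configuration as drawn.

On these data alone, it remains open whether the same small step would hold with a longer chain or a carboxylic acid at this stereocentre, where the difference between S and R might read otherwise. As far as these compounds go, it also remains open whether inverting any of the other stereo elements of the shared core would leave the number as little moved.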